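Side group exchange on the amide: compound 2 to compound 4

A few compounds are considered here, and "the series" means these few. Any claim that something is new, unique, unknown or untested is made for them only; others in the source may bear on it.

In an ADME assay on microsomes from liver (Homo sapiens) for metabolic stability (a higher number here means that the compound lasts longer, a lower number that the compound disappears faster), compound 2 `O=C(NCCSc1nonc1/C(=N/O)Nc1ccc(F)c(C(F)F)c1)C1CS(=O)(=O)C1` gives 1.28 h. Compound 1 `CC1(C(=O)NCCSc2nonc2/C(=N/O)Nc2ccc(F)c(C(F)F)c2)CCN1` gives 1.97 h and compound 3 `C[C@@H](CSc1nonc1/C(=N/O)Nc1ccc(F)c(Br)c1)NC(=O)CS(N)(=O)=O` gives 1.57 h. Both values lie within the scatter of the value for compound 2, so the three numbers form a single band with no meaningful order.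

The next change leads to compound 4 `CC(C)(O)CC(=O)NCCSc1nonc1/C(=N/O)Nc1ccc(F)c(C(F)F)c1` and is a group of 5 heavy atoms (4 carbon, 1 oxygen; no ring) in place of a group of 6 heavy atoms (3 carbon, 2 oxygen, 1 sulfur; one four-membered non-aromatic ring with 1 hetero atom), on a carbonyl carbon. The entering group is 2-hydroxy-2-methylpropyl, and it stands on a carbonyl carbon whose other neighbours are: amide-type nitrogen.

Among the measured compounds shown here, one measured step bears directly on this change, at the same kind of carbonyl carbon: a 1.5-fold lower number from compound 1 to compound 2 (0.19 log units; within the scatter). That step stays within the scatter, but both of its groups hold one four-membered non-aromatic ring with 1 hetero atom, so it does not cover the loss of the ring. For the measured compounds named here, compound 3, at 1.57 h, has no ring in the group on its carbonyl carbon, but it differs from compound 2 in more than one place and gives no clean step.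

Going by the values given here, with only this evidence, no change beyond the scatter is expected. The estimated step is a 1.2-fold higher number from compound 2 to compound 4 (0.07 log units; within the scatter). In this assay the estimate for compound 4 is 1.5 h, with an expected range of 0.9 h to 2.5 h.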

Compound 4, half-life: 0.937 h
Compound 4: middle estimate off by 1.6-fold (0.20 log units), on the high side; low and high end bracket the measured number.
By their numbers in this assay, from the lowest: compounds 4, 2, 3 and 1 (each within the scatter of the next, the first and the last beyond it).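

In this assay, placing the open-chain 2-hydroxy-2-methylpropyl group on the carbonyl carbon gives a 1.4-fold lower number from compound 2 to compound 4 (0.14 log units; within the scatter), so a group without a ring is now measured at this position, and that step alone does not separate it from the ring-bearing group of 6 heavy atoms. Against the other ring-bearing group, the group of 5 heavy atoms with one nitrogen, the same exchange gives a 2.1-fold lower number from compound 1 to compound 4 (0.32 log units; beyond the scatter), the first step at this position to pass beyond the scatter, and a modest one. No measurement bears on the reason for this step.

The compounds shown do not separate the part played by the loss of the ring from that of the entering hydroxyl, and an open-chain alkyl group without a hydroxyl on the same carbonyl carbon would bear on that question. They also leave open how an open-chain amine or a carboxylic acid at this place would behave, and whether a longer chain would widen or close the gap seen here between compound 1 and compound 4.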